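A few compounds are considered here, and "the series" means these few. Any claim that something is new, unique, unknown or untested is made for them only; others in the source may bear on it.

Compound 1 `C=CC(C)(C/C=C(\C)CCC=C(C)C)c1ccc(OCc2ccccc2)c(OCc2ccccc2)c1`: "not active" (no number reported)
Compound 2 `C=CC(C)(C/C=C(\C)CCC=C(C)C)c1ccc(O)c(OCc2ccccc2)c1`: 12.4 ug/mL

Both compounds were tested in a functional assay on HL-60 cells (Homo sapiens) for cytotoxicity, read by MTT assay, with a stated time of 72 h; a lower number here means a stronger inhibitor, a higher number a weaker inhibitor. For the measured compounds named here, compound 2, at 12.4 ug/mL, holds the only number so far, and compound 1 gave no number to compare it with. On these data alone, its place in any ranking is therefore still open.

Compound 3 `C=CC(C)(C/C=C(\C)CCC=C(C)C)c1ccc(O)c(OC)c1` has not yet been measured. It differs from compound 2 in one place: hydrogen in place of phenyl on a saturated chain carbon bound to an oxygen on an aromatic ring. Hydrogen takes the place of phenyl on a saturated chain carbon bound to an oxygen on an aromatic ring, so that benzyloxy becomes methoxy.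

Going by the values given here, no measured pair of compounds shows what a single change of this kind does. The expectation in this assay is therefore cautious, with no step beyond the scatter and no firm direction. The expected change is a 1.2-fold lower number from compound 2 to compound 3 (0.09 log units; within the scatter). For compound 3 the estimated value is 10 ug/mL, within an expected range of 4 ug/mL to 28 ug/mL.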

Compound 3, half-maximal inhibitory concentration: 14.4 ug/mL
Beside the measured number, compound 3's estimate is 1.4-fold (0.16 log units) below it, within the range that was stated.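

In this assay the change from benzyloxy to methoxy gives a 1.2-fold higher number from compound 2 to compound 3 (0.06 log units; within the scatter) and so leaves compound 2 and compound 3 indistinguishable. For the compounds shown here, this is the first reading of a single change at this place, a saturated chain carbon bound to an oxygen on an aromatic ring. Here a phenyl of six carbon atoms can give way to hydrogen with no change in the number that stands out from the usual scatter of the assay. No measured property of either group is available to explain this result.

The compounds shown leave open what a free hydroxyl in place of the methoxy, or a longer chain such as butoxy on that oxygen, would do. Also open, on these data alone, is whether a pyridyl in place of the phenyl would read the same.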